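The source may hold more compounds than are shown below. What is called first, only, known or untested is meant among the compounds shown, and "the series" means these compounds.

Measured so far:
Compound 1, `Nc1cc(N)c2nc(-c3ccccc3)c(NCc3ccc(Cl)c(Cl)c3)nc2c1`, gives 4470 nM in a functional assay on MDA-MB-231 cells (Homo sapiens) for inhibition, read by sulforhodamine B assay, with a stated time of 48 h; a lower number here means a stronger inhibitor of growth, a higher number a weaker inhibitor of growth.
Compound 2, `COc1ccc(CNc2nc3cc(N)cc(N)c3nc2-c2ccccc2)cc1OC`, gives 29500 nM.
Compound 3, `Nc1cc(N)c2nc(-c3ccccc3)c(NCc3ccc(F)cc3)nc2c1`, gives 5130 nM.

Among these three numbers compound 3 stands second highest; its nearest neighbour is compound 1 and its farthest is compound 2. The step of a 1.1-fold higher number from compound 1 to compound 3 (0.06 log units; within the scatter) lies within the scatter, while the step of a 5.8-fold lower number from compound 2 to compound 3 (0.76 log units; beyond the scatter) lies beyond it.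

Compound 4, `COc1ccc(CNc2nc3cc(N)cc(N)c3nc2-c2ccccc2)cc1`, differs from compound 3 in one place: methoxy in place of fluoro on an aromatic carbon. Among the measured compounds shown here, no measured step swaps exactly this pair, but two bear on it. Two methoxy groups in place of two chlorines gave a 6.6-fold higher number from compound 1 to compound 2 (0.82 log units; beyond the scatter), and fluoro in place of those two methoxy groups gave a 5.8-fold lower number from compound 2 to compound 3 (0.76 log units; beyond the scatter); in both, the methoxy-bearing compound gives the higher number. A single methoxy is therefore expected to raise the number, by less than those steps, a 2.3-fold higher number from compound 3 to compound 4 (0.37 log units; beyond the scatter). Compound 4 is estimated at 12000 nM, in the range 5000 nM to 30000 nM.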

Compound 4, concentration for total growth inhibition: 13800 nM
Compound 4: middle estimate off by 1.2-fold (0.06 log units), on the low side; the range from low to high includes it.
By their numbers in this assay, from the lowest: compounds 1 and 3 (each within the scatter of the next); then compound 4; then compound 2.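

Among the compounds shown here, compound 4 gives the first reading of a single methoxy in place of fluoro at this position, without a second group changing alongside it: a 2.7-fold higher number from compound 3 to compound 4 (0.43 log units; beyond the scatter). The methoxy-bearing compound 4 also sits apart from its other two neighbours, with a 2.1-fold lower number from compound 2 to compound 4 (0.33 log units; beyond the scatter) on removing the additional methoxy and a 3.1-fold higher number from compound 1 to compound 4 (0.49 log units; beyond the scatter) against the 3,4-dichlorophenyl group. No measured evidence here explains these steps. Still open, going by these compounds, is how an amine or a hydroxy group at this position would compare with methoxy and fluoro. On these data alone, a longer ether, such as ethoxy, is also open.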